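Compound 3: A New Group on the Double-Bonded Nitrogen

The source may hold more compounds than are shown below. What is called first, only, known or untested is meant among the compounds shown, and "the series" means these compounds.

Measured in an ADME assay on RAW264.7 cells (Mus musculus) for inhibition, read by MTT assay, with a stated time of 72 h, tested at 100 uM; a lower number here means less inhibition of growth, a higher number more inhibition of growth at the concentration tested:
- compound 1 `O=C(N/N=C(/N=N/c1ccccc1Cl)c1ccccc1)c1cc(O)c(O)c(O)c1` gives 32.7%
- compound 2 `COc1ccc(/N=N/C(=N/NC(=O)c2cc(O)c(O)c(O)c2)c2ccccc2)cc1` gives 15%

Of these two compounds, compound 2 has the lower number, and the gap to compound 1 is beyond the usual scatter. The next compound is compound 3 `O=C(N/N=C(/N=N/c1ccccc1[N+](=O)[O-])c1ccccc1)c1cc(O)c(O)c(O)c1`, and the change is 2-nitrophenyl in place of 4-methoxyphenyl on a double-bonded nitrogen. Put simply, 2-nitrophenyl takes the place of 4-methoxyphenyl on a double-bonded nitrogen.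

Among the measured compounds shown here, only one measured step bears on this: a number 17.7 percentage points lower from compound 1 to compound 2 (beyond the scatter). For the measured compounds named here, that modest step is the only evidence on this position, and it comes from a different incoming group. Going by the values given here, no measured compound carries 2-nitrophenyl, so the range must stay wide. A rise of similar or somewhat smaller size in this assay is expected, and the expected step is a number 13 percentage points higher from compound 2 to compound 3 (beyond the scatter). The estimate for compound 3 is 28%, with an expected range of 12% to 45%.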

Compound 3, percent growth inhibition at one concentration: 5.43%
For compound 3 the middle estimate is 22.6 percentage points above the measured one, and the stated range ends above it.
By their numbers in this assay, from the lowest: compounds 3 and 2 (each within the scatter of the next); then compound 1.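

In this assay, exchanging one ring substituent pattern for another at the double-bonded nitrogen gives a number 9.6 percentage points lower from compound 2 to compound 3 (within the scatter), so two quite different groups, 4-methoxyphenyl and 2-nitrophenyl, cannot be told apart at this position. The comparison with the chloro compound is clearer: a number 27.3 percentage points lower from compound 1 to compound 3 (beyond the scatter), a change of a single group on an aromatic carbon that is large enough to stand out from the scatter. Among these compounds, then, 2-chlorophenyl alone stands apart, while a substituent at the same ring place can give a clearly different result, and nothing measured here explains why.

From the compounds shown here alone, it remains open whether the chloro group's effect depends on where it sits, as a 4-chlorophenyl group could show. An amine or a carboxylic acid on the ring, or a plain phenyl group, would test how far this position tolerates change.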